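This account rests on a few compounds, and the source may have more. Where it says the series, first, only, none or still open, it means among the compounds named here.

Measured compounds:
- compound 1, `[N-]=[N+]=NCc1ncnc2c1ncn2[C@@H]1O[C@H](CO)[C@@H](O)[C@H]1O`; in a functional assay on Huh-7 cells (Homo sapiens) for cytotoxicity, read by MTT assay, with a stated time of 3 days (on this read-out lower numbers stand for higher toxicity in this test and higher numbers for lower toxicity in this test), compound 1 gives > 250000 nM, which is a limit of the assay and not a number.
- compound 2, `CN(Cc1ccccc1)Cc1ncnc2c1ncn2[C@@H]1O[C@H](CO)[C@@H](O)[C@H]1O`; in this assay compound 2 gives 9000 nM.
- compound 3, `OC[C@H]1O[C@@H](n2cnc3c(Cn4cccn4)ncnc32)[C@H](O)[C@@H]1O`; in this assay compound 3 gives > 250000 nM, again a limit of the assay.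

Compound 3 therefore stands at the limit of the assay, where compound 1 also sits (the limit of > 250000 nM in this assay, at which 2 of the 3 values shown sit); only compound 2 gives a number. Compound 4, `O=c1ccccn1Cc1ncnc2c1ncn2[C@@H]1O[C@H](CO)[C@@H](O)[C@H]1O`, is not yet measured. Its change from compound 3: a group of 7 heavy atoms (5 carbon, 1 nitrogen, 1 oxygen; one six-membered aromatic ring with 1 hetero atom) in place of a group of 5 heavy atoms (3 carbon, 2 nitrogen; one five-membered aromatic ring with 2 hetero atoms), on a saturated chain carbon bound to an aromatic carbon. The measured steps that bear on it are an at least 27-fold higher number from compound 2 to compound 3 (1.44 log units; beyond the scatter), a large step, and a step that the two limits leave unreadable from compound 1 to compound 3; both end at the 1H-pyrazol-1-yl that now leaves. Among the measured compounds shown here, neither step shows what exchanging one neutral aromatic ring for another does, and the only compound with a number, compound 2, carries the benzyl(methyl)amino instead. The expected step of an at least 1.2-fold lower number from compound 3 to compound 4 (0.09 log units; that floor lies within the scatter) is accordingly none beyond the scatter, with compound 4 expected to remain at the limit. Compound 4 is estimated at 200000 nM in this assay, within 60000 nM to 250000 nM.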

Compound 4, half-maximal cytotoxic concentration: > 100000 nM
Compound 4: no number, only a limit (the forecaster's own chance of this, stated with the estimate: 70%); the middle value is on the limit's open side.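

In this assay compound 4 gives > 100000 nM, which is a limit of the assay and not a number. On the saturated chain carbon bound to an aromatic carbon, the six-membered aromatic ring with 1 hetero atom therefore also gives no number, as with the azido of compound 1 and the 1H-pyrazol-1-yl of compound 3, while compound 2 goes against this pattern, with the step reading an at least 11-fold higher number from compound 2 to compound 4 (1.04 log units; beyond the scatter). The steps from compound 1 and from compound 3 to compound 4 cannot be read, as both ends are limits.

Going by these compounds, whether the number of compound 2 goes with its amine nitrogen or with its benzyl ring stays open. A dimethylamino group or a primary amine on the same carbon would separate the two.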